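Replacing the benzoxazolyl sulfanyl arm on the shared core

The source may hold more compounds than are shown below. What is called first, only, known or untested is meant among the compounds shown, and "the series" means these compounds.

Measured so far:
compound 1 `Cn1c(-c2ccc(NC(=O)CSc3nc4ccccc4o3)cc2)nc(-c2ccccc2)c1-c1ccccc1`: 76.3%
compound 2 `Cn1ccnc1SCC(=O)Nc1ccc(-c2nc(-c3ccccc3)c(-c3ccccc3)n2C)cc1`: 64%
compound 3 `CN(C)/C=C/N1CCN(CC(=O)Nc2ccc(-c3nc(-c4ccccc4)c(-c4ccccc4)n3C)cc2)CC1`: 34.7%

All three share one core and differ only in the arm on the saturated chain carbon bound to the carbonyl carbon, read in a functional assay on MCF7 cells (Homo sapiens) for cytotoxicity, read by MTT assay, with a stated time of 24 h, tested at 80 ug/mL; on this read-out higher numbers stand for a stronger effect at the one concentration tested and lower numbers for a weaker effect. Compound 1 stands highest of the three; compound 2 lies nearest, a number 12.3 percentage points lower from compound 1 to compound 2 (beyond the scatter), and compound 3 furthest, a number 41.6 percentage points lower from compound 1 to compound 3 (beyond the scatter). Compound 4 `Cn1c(-c2ccc(NC(=O)CN3CCN(c4ccccc4)CC3)cc2)nc(-c2ccccc2)c1-c1ccccc1` is not yet measured; it differs from compound 1 by 4-phenylpiperazin-1-yl in place of (1,3-benzoxazol-2-yl)sulfanyl on a saturated chain carbon bound to a carbonyl carbon. The step that bears most on it is a number 41.6 percentage points lower from compound 1 to compound 3 (beyond the scatter), where the sulfanyl arm likewise gave way to a piperazin-1-yl group; a number 29.3 percentage points lower from compound 2 to compound 3 (beyond the scatter) points the same way. For compound 4 a large fall is therefore expected, a number 36.3 percentage points lower from compound 1 to compound 4 (beyond the scatter). Compound 4 is estimated at 40%, between 25% and 56%.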

Compound 4, a percentage reported as activity, at one concentration (the size of the read-out at that concentration, not a potency): 72.5%
Compound 4: the middle estimate sits 32.5 percentage points below what was measured, and the stated range ends below it.
By their numbers in this assay, from the lowest: compound 3; then compounds 2, 4 and 1 (each within the scatter of the next, the first and the last beyond it).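

In this assay, a piperazin-1-yl arm alone does not bring the loss seen earlier: 4-phenylpiperazin-1-yl on the saturated chain carbon bound to a carbonyl carbon reads level with both sulfanyl arms (a number 3.8 percentage points lower from compound 1 to compound 4 (within the scatter); a number 8.5 percentage points higher from compound 2 to compound 4 (within the scatter)). Between the two piperazines, the group on the ring amine nitrogen matters, with phenyl in place of 2-(dimethylamino)ethenyl giving a large step (a number 37.8 percentage points higher from compound 3 to compound 4 (beyond the scatter)). Open, on these data alone, is whether a benzyl or a plain methyl group on that nitrogen holds the read-out, as phenyl does, or loses it. Nothing available explains this difference.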